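The source may hold more compounds than are shown below. What is called first, only, known or untested is meant among the compounds shown, and "the series" means these compounds.

Measured in an ADME assay on HCT-116 cells (Homo sapiens) for cytotoxicity, read by CellTiter-Glo, with a stated time of 72 h (on this read-out lower numbers stand for stronger inhibition and higher numbers for weaker inhibition), each entry a limit of the assay:
- compound 1 `CC1CCN(C2CCN(S(=O)(=O)c3cccnc3Cl)CC2)CC1`: > 10000 nM
- compound 2 `Cc1cccc(S(=O)(=O)N2CCC(N3CCC(C)CC3)CC2)c1`: > 5000 nM
- compound 3 `CC1CCN(C2CCN(S(=O)(=O)c3cccnc3F)CC2)CC1`: > 10000 nM

Compound 3 gives > 10000 nM, which is a limit and not a number. Compound 4 `CC1CCN(C2CCN(S(=O)(=O)c3ccc(Br)c(Cl)c3)CC2)CC1` carries 4-bromo-3-chlorophenyl in place of 2-fluoropyridin-3-yl on a sulfonyl sulfur.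

Two measured steps change the group at this place: a step that the two limits leave unreadable from compound 1 to compound 2 and a step that the two limits leave unreadable from compound 2 to compound 3. Neither gives a readable size or direction, and a step that the two limits leave unreadable from compound 1 to compound 3 is no more informative. A modest move toward stronger inhibition in this assay is therefore expected, with little confidence, and the expected change is an at least 1.4-fold lower number from compound 3 to compound 4 (0.15 log units; that floor lies within the scatter). For compound 4 the estimated value is 7000 nM, with an expected range from 1500 nM to 15000 nM.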

Compound 4, half-maximal inhibitory concentration: > 5000 nM
Compound 4: no number, only a limit; the forecaster's own chance of this, stated with the estimate: 60%; the middle value lies beyond the limit too.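

Among the compounds shown here, compound 4, like compound 1, compound 2 and compound 3, has only a limit in this assay, and no step among them can be read. The compounds shown leave open whether any group on the sulfonyl sulfur changes the read-out in this assay.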